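Configuration of the hydroxymethylcyclohexyl ether: compound 2 to compound 3

A few compounds are considered here, and "the series" means these few. Any claim that something is new, unique, unknown or untested is made for them only; others in the source may bear on it.

Going by the values given here, in a functional assay on CAL-51 cells (Homo sapiens) for antiproliferative activity, read by luminescence and CellTiter-Glo, with a stated time of 3 days (on this read-out lower numbers stand for stronger inhibition and higher numbers for weaker inhibition), compound 1 `COc1cc(C(=O)N(C)C)ccc1Nc1nc(OC2CCCC2)c2cc[nH]c2n1` gives 497 nM and compound 2 `COc1cc(C(=O)N(C)C)ccc1Nc1nc(O[C@H]2CC[C@@](C)(O)CC2)c2cc[nH]c2n1` gives 44 nM, the lower of the two numbers so far. Compound 3 `COc1cc(C(=O)N(C)C)ccc1Nc1nc(O[C@H]2CC[C@](C)(O)CC2)c2cc[nH]c2n1` is the next to be read against compound 2: the two compounds have the same atoms and bonds and differ only in configuration as drawn: 2 of 2 stereo elements differ (all stereocentres are inverted: mirror images); a stereocentre at a saturated ring carbon is drawn s in compound 2 and r in compound 3; a stereocentre at a saturated ring carbon is drawn s in compound 2 and r in compound 3.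

Among the compounds with values here, only one measured step bears on this, and only indirectly: an 11-fold lower number from compound 1 to compound 2 (1.05 log units; beyond the scatter). Within the data shown here, that large step is a change of group, not of configuration, so no measured pair shows what configuration alone does in this assay. It does show that the number can move widely with the group on that oxygen, so a real shift cannot be ruled out. A moderate move toward a higher number is expected, with a 2.0-fold higher number from compound 2 to compound 3 (0.31 log units; beyond the scatter) as the estimated step. For compound 3 the estimated value is 90 nM, with an expected range of 25 nM to 350 nM.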

Compound 3, half-maximal inhibitory concentration: 69 nM
Compound 3: the middle estimate sits 1.3-fold (0.12 log units) above what was measured, and the stated range covers the measured number.
By their numbers in this assay, from the lowest: compounds 2 and 3 (each within the scatter of the next); then compound 1.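

In this assay, inverting both drawn stereocentres of the 4-hydroxy-4-methylcyclohexyl ether gives a 1.6-fold higher number from compound 2 to compound 3 (0.20 log units; within the scatter), so this pair shows no separation by configuration, and no other structural change enters the comparison: the fact that compounds 2 and 3 differ only in the configuration as drawn. The gain over the cyclopentyl ether is therefore not tied to one drawn configuration, as it also appears as a 7.2-fold lower number from compound 1 to compound 3 (0.86 log units; beyond the scatter). Among these three compounds, the change of group on the oxygen moves the number beyond the scatter, whereas the change of configuration does not.

The hydroxyl and the methyl enter together in both compounds, leaving open which of them accounts for the step from cyclopentyl. As far as these compounds go, how an amine or a carboxylic acid in place of that hydroxyl would read also remains open.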